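The source may hold more compounds than are shown below. What is called first, only, known or untested is meant among the compounds shown, and "the series" means these compounds.

Measured compounds:

- compound 1, `CCCCCCCNc1cnc(C(=O)NCc2ccccc2)cn1`, in an ADME assay on MDCK cells (Canis lupus familiaris) for cytotoxicity, read by microscopy, with a stated time of 6 days; a higher number here means that more compound is tolerated, a lower number that less compound is tolerated: > 100000 nM
- compound 2, `CCCCCCNc1cnc(C(=O)NCc2ccccc2)cn1`: > 100000 nM
- compound 3, `CCCCCCNc1nccnc1C(=O)NCc1ccccc1`: 100000 nM

The values of compound 1 and compound 2 are limits of this assay, not numbers. Compound 3 is the only one of the three with a numerical reading, and both the other values sit at the limit of > 100000 nM in this assay, at which 2 of the 3 values shown sit. Compound 2 and compound 1 share one core; compound 3 carries a different one, and the difference between the two cores is not broken down here.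

The change from compound 2 to compound 1 is methyl in place of hydrogen on a saturated chain carbon, six bonds along the chain from a nitrogen on an aromatic ring, and the step it gives, a step that the two limits leave unreadable from compound 2 to compound 1, cannot be read because both ends are limits. Compound 4, `CCCCCCCNc1nccnc1C(=O)NCc1ccccc1`, is not yet measured; it differs from compound 3 by methyl in place of hydrogen on a saturated chain carbon, six bonds along the chain from a nitrogen on an aromatic ring, the same change placed on the other core.

With the earlier step unreadable and compound 3 sitting at the edge of the readable range, a step near zero is expected from compound 3 to compound 4, no change at the digits printed from compound 3 to compound 4 (within the scatter), and compound 4 is estimated at 100000 nM, with a good chance that only a limit is reported.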

Compound 4, minimum cytotoxic concentration: 100000 nM
For compound 4 middle estimate and measured number coincide at the digits printed; low and high end bracket the measured number.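

In this assay methyl in place of hydrogen on a saturated chain carbon, six bonds along the chain from a nitrogen on an aromatic ring, gives no change at the digits printed from compound 3 to compound 4 (within the scatter) on the second core, so on that core this change leaves the reading in place. The matching step on the core shared by compound 1 and compound 2 cannot be read because both of its ends are limits of the assay and not numbers: the limit of > 100000 nM in this assay, at which 2 of the 4 values shown sit. The series therefore offers one readable step on one core, which shows no change there but does not show that the change behaves alike on both cores.

Going by these compounds, it remains open whether a longer chain, or an amine or a carboxylic acid at the end of the chain, would shift the reading in this assay on either core. On these data alone, the contribution of the difference between the two cores also remains open.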